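Trading a Pyrrolidinyl Group for a Benzyloxy Group

The compounds below may be only part of what the source reports. "The series", "measured", "known", "first", "only" and "open" are said of these compounds alone.

Compound 1 `CC(C(=O)NCc1ccc(C(C)(C)C)nc1OCc1ccc(F)cc1)c1ccc(NS(C)(=O)=O)c(F)c1`: 0.8 nM
Compound 2 `CC(C(=O)NCc1ccc(C(C)(C)C)cc1N1CCCC1)c1ccc(NS(C)(=O)=O)c(F)c1`: 8.1 nM

In an assay on cells for antagonist activity at transient receptor potential cation channel subfamily V member 1 (Homo sapiens), read by FLIPR and calcium flux, with a stated time of 6 min (a lower number here means a stronger inhibitor, a higher number a weaker inhibitor), compound 1 gives 0.8 nM, while compound 2 gives 8.1 nM, the highest of the two numbers and well beyond the scatter from compound 1. Compound 3 `CC(C(=O)NCc1ccc(C(C)(C)C)cc1OCc1ccccc1)c1ccc(NS(C)(=O)=O)c(F)c1` has not been measured. It differs from compound 2 in one place: benzyloxy in place of pyrrolidin-1-yl on an aromatic carbon. Because compound 1, which also carries a benzyloxy-type group at that place, gives 0.8 nM, compound 3 is expected to land closer to it, with a step of a 5.4-fold lower number from compound 2 to compound 3 (0.73 log units; beyond the scatter) toward a stronger inhibitor. Compound 3 is thus estimated at 1.5 nM, between 0.5 nM and 5 nM.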

Compound 3, inhibition constant: 2.9 nM
Beside the measured number, compound 3's estimate is 1.9-fold (0.29 log units) below it; measured number inside the range.
By their numbers in this assay, from the lowest: compound 1; then compound 3; then compound 2.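

At this position, on an aromatic carbon ortho to a large group and meta to a tert-butyl group, benzyloxy in place of pyrrolidin-1-yl gives a 2.8-fold lower number from compound 2 to compound 3 (0.45 log units; beyond the scatter) in this assay. The position therefore accepts a group of 8 heavy atoms with a six-membered aromatic ring in place of one of 5 heavy atoms, and the hydrogen-bond acceptor and donor counts stay the same across the change. No measurement shown here accounts for the size of this step. Still open, going by these compounds, is how a morpholin-4-yl group, a carboxylic acid or a longer phenethyloxy chain would fare at this place.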